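Replacing (vinylcarbonyl)oxy with sulfanyl: a stability forecast

A few compounds are considered here, and "the series" means these few. Any claim that something is new, unique, unknown or untested is made for them only; others in the source may bear on it.

Compound 1, `C=CC(=O)Oc1cc(C(F)(F)F)cc(C(F)(F)F)c1`, was tested in an ADME assay for pharmacokinetics, read by HPLC, in phosphate buffer, with a stated time of 72 h, at pH 7.4, tested at 250 uM; a lower number here means that the compound disappears faster, a higher number that the compound lasts longer. In this assay compound 1 reaches only < 0.017 h, which is a limit of the assay rather than a number (the limit of < 0.017 h in this assay, at which 1 of the 2 values shown sits). Compound 2, `Fc1cc(C(F)(F)F)cc(C(F)(F)F)c1`, gives 11 h in this assay. Compound 3, `FC(F)(F)c1cc(S)cc(C(F)(F)F)c1`, differs from compound 1 in one place: sulfanyl in place of (vinylcarbonyl)oxy on an aromatic carbon. Within the data shown here, the only measured step touching this position is an at least 640-fold higher number from compound 1 to compound 2 (2.81 log units; beyond the scatter), a large rise. A rise of similar kind is therefore expected, estimated as an at least 470-fold higher number from compound 1 to compound 3 (2.67 log units; beyond the scatter). Compound 3 is expected to give about 8 h, in a range from 1 h to 40 h.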

Compound 3, half-life: 31.5 h
Compound 3: the middle estimate sits 3.9-fold (0.60 log units) below what was measured; measured number inside the range.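

Sulfanyl, like fluoro, gives a large rise in this assay when it replaces (vinylcarbonyl)oxy, with an at least 1800-fold higher number from compound 1 to compound 3 (3.26 log units; beyond the scatter) as the step, so the rise does not belong to fluoro alone. The two replacements do not end level, with a 2.9-fold higher number from compound 2 to compound 3 (0.46 log units; beyond the scatter) separating them. The true size of the rise stays unknown, since compound 1 stands at a limit of the assay and not at a number: the limit of < 0.017 h in this assay, at which 1 of the 3 values shown sits.

Going by these compounds, how an amine, a carboxylic acid or a longer chain would fare at this position stays open. Also open, on these data alone, is whether an amide, which keeps the carbonyl, would last as long.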